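Ethoxy gives way to isopropyl on the shared core

The source may hold more compounds than are shown below. What is called first, only, known or untested is meant among the compounds shown, and "the series" means these compounds.

Measured in an ADME assay on J774 cells (Mus musculus) for cytotoxicity; a higher number here means that more compound is needed for the effect, a lower number that less compound is needed:
Compound 1 `COC(=O)c1c[nH]c2ccc(OC)cc2c1=O`: 6180 nM
Compound 2 `CCOc1ccc2[nH]cc(C(=O)OC)c(=O)c2c1`: > 20000 nM (a limit, not a number)

From the compounds shown here alone, compound 2 stands at the limit of > 20000 nM in this assay, at which 1 of the 2 values shown sits, so its true position is unknown. Compound 3 `COC(=O)c1c[nH]c2ccc(C(C)C)cc2c1=O` carries isopropyl in place of ethoxy on an aromatic carbon. Within the data shown here, only one measured step bears on this change: an at least 3.2-fold higher number from compound 1 to compound 2 (0.51 log units; beyond the scatter). Among the measured compounds shown here, that step altered the same chain, but it kept the oxygen, and no measured compound lacks that oxygen. The evidence is therefore indirect. For the measured compounds named here, compound 1, at 6180 nM, gives the only true number nearby, so a modest expected move toward a lower number in this assay seems reasonable. Compound 3 may also reach the limit of compound 2. The expected change is an at least 1.5-fold lower number from compound 2 to compound 3 (0.18 log units; that floor lies within the scatter). For compound 3, the estimated value is 13000 nM, with an expected range of 5000 nM to 30000 nM.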

Compound 3, half-maximal effective concentration: > 20000 nM
Compound 3 was reported as a limit; the forecaster's own chance of this, stated with the estimate: 40%; at least 1.5-fold (0.18 log units) between middle value and limit.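

In this assay, the change at this position now has a readable step without the oxygen on the aromatic carbon: isopropyl in place of methoxy gives an at least 3.2-fold higher number from compound 1 to compound 3 (0.51 log units; beyond the scatter). The earlier readable step, an at least 3.2-fold higher number from compound 1 to compound 2 (0.51 log units; beyond the scatter), had kept that oxygen, so the new step shows that a higher number in this assay does not require it. The step between compound 2 and compound 3 cannot be read, since both are reported only as limits: the limit of > 20000 nM in this assay, at which 2 of the 3 values shown sit.

From the compounds shown here alone, how far the true values of compound 2 and compound 3 lie past that limit remains open, as does whether these two differ at all. Also open, going by these compounds, is whether an amine or a carboxylic acid on this aromatic carbon would bring the number back down.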